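This account rests on a few compounds, and the source may have more. Where it says the series, first, only, none or still open, it means among the compounds named here.

Working notes on the series

All members share one core, and the three measured compounds differ only in where the ring nitrogen and the bromo sit on the aromatic ring. In an assay on K177 cells with Neuronal acetylcholine receptor; alpha4/beta2 (Homo sapiens) as the target (a higher number here means a larger maximal response, a lower number a smaller maximal response), compound 1 `CN1CCC[C@H]1COc1cccnc1Br` gives 12.3%. In this assay compound 2 `CN1CCC[C@H]1COc1cnccc1Br` gives 14.1%. In this assay compound 3 `CN1CCC[C@H]1COc1cncc(Br)c1` gives 41.8%, the highest of the three numbers; the nearest is compound 2, lower by a margin beyond the scatter, and the furthest is compound 1, also beyond the scatter. Going by the values given here, no two of the measured compounds differ in a single place, so no measured step exists within the set.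

The next compound, compound 4 `CCc1cncc(OC[C@@H]2CCCN2C)c1`, follows from compound 3 by one change: ethyl in place of bromo on an aromatic carbon. Among the compounds with values here, nothing among the measured compounds shows what an ethyl in place of a bromo does at this position, so the expectation rests on compound 3 alone and carries a wide range. A step of modest size, downward or none beyond the scatter, is expected in this assay. Compound 4 is expected to give 35%, with a range from 15% to 60%. That estimate corresponds to an expected step of a number 6.8 percentage points lower from compound 3 to compound 4 (within the scatter).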

Compound 4, largest response reached (reported as maximum), in percent of the reference or control that the assay uses: 33.7%
Estimate against measurement, compound 4: 1.3 percentage points above; the range from low to high includes it.
By their numbers in this assay, from the lowest: compounds 1 and 2 (each within the scatter of the next); then compounds 4 and 3 (each within the scatter of the next).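

Ethyl in place of bromo on this aromatic carbon, two atoms from the ring nitrogen, gives in this assay a number 8.1 percentage points lower from compound 3 to compound 4 (within the scatter), so at this position the bromo can give way to ethyl with no change beyond the scatter. This is the first step in the series that can be read at a single place, something the earlier compounds, which differ from one another in where the ring nitrogen and the bromo sit, could not offer, and it shows that on this core the maximal response does not depend on bromo specifically among these two groups. Nothing measured here bears on why the two groups behave alike in this read-out.

On these data alone, one step with two groups does not show how far this tolerance reaches, so it remains open whether a longer chain such as propyl or butyl, an amine, or a carboxylic acid on the same aromatic carbon would hold the maximal response. As far as these compounds go, it also remains open whether plain hydrogen at this carbon would do the same, and whether ethyl would behave alike at the other ring carbons.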